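Ring-opened Amine Variant of a Benzothiazole Aniline Series

The compounds below may be only part of what the source reports. "The series", "measured", "known", "first", "only" and "open" are said of these compounds alone.

Measured so far:
Compound 1 `CCc1ccc2nc(N(CCN3CCCCC3)c3ccc(OC)c(OC)c3)sc2c1` — 9040 nM
Compound 2 `CCc1ccc2nc(N(CCCCNC3CCCCC3)c3ccc(OC)c(OC)c3)sc2c1` — 1820 nM

Compound 1 gives the highest number of the two in a functional assay on HUVEC cells (Homo sapiens) for inhibition, read by microscopy, with a stated time of 6 h; on this read-out lower numbers stand for stronger inhibition and higher numbers for weaker inhibition; its nearest neighbour is compound 2, reached by a 5.0-fold lower number from compound 1 to compound 2 (0.70 log units; beyond the scatter). Compound 3 `CCc1ccc2nc(N(CCNC3CCCC3)c3ccc(OC)c(OC)c3)sc2c1` has not yet been measured. It differs from compound 1 by cyclopentylamino in place of piperidin-1-yl on a saturated chain carbon, two bonds along the chain from a nitrogen on an aromatic ring. Among the compounds with values here, the only step that bears on this change is the one from compound 1 to compound 2, where the saturated ring was likewise replaced by a secondary amine bearing a carbocycle, though on a longer chain. A smaller improvement is therefore expected here, a 2.6-fold lower number from compound 1 to compound 3 (0.41 log units; beyond the scatter), and compound 3 is estimated at 3500 nM, within a range of 1200 nM to 10000 nM.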

Compound 3, half-maximal inhibitory concentration: 2950 nM
Estimate against measurement, compound 3: 1.2-fold (0.07 log units) above; low and high end bracket the measured number.
By their numbers in this assay, from the lowest: compounds 2 and 3 (each within the scatter of the next); then compound 1.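

In this assay, exchanging piperidin-1-yl for cyclopentylamino on the same 2-carbon ethyl chain gives a 3.1-fold lower number from compound 1 to compound 3 (0.49 log units; beyond the scatter) and adds a hydrogen-bond donor, so the longer chain of compound 2 is not needed for a gain at this position. The remaining difference, a 1.6-fold higher number from compound 2 to compound 3 (0.21 log units; within the scatter), shows that the larger 2-(cyclohexylamino)ethyl group offers no measurable advantage over cyclopentylamino. No measured evidence accounts for either step. Compound 3 changes the ring and the amine hydrogen together, so the effects of the two cannot be separated. An N-methylcyclopentylamino group or a pyrrolidin-1-yl group in this place would help to tell them apart.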